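The compounds below may be only part of what the source reports. "The series", "measured", "known", "first", "only" and "open" are said of these compounds alone.

In a functional assay on M21 cells (Homo sapiens) for inhibition, read by sulforhodamine B assay, with a stated time of 48 h (a lower number here means a stronger inhibitor of growth, a higher number a weaker inhibitor of growth), compound 1 (`Cc1ccc(NC2=NCCO2)cc1C`) reads 5100 nM and compound 2 (`O=C(CCl)NC(=O)Nc1ccc(-c2ccccc2)cc1`) reads 1400 nM while compound 3 (`O=C(CCl)NC(=O)Nc1ccc(OC2CCCC2)cc1`) reads 2900 nM on the same scale. Compound 3 thus lies within the scatter of compound 1 and clearly above compound 2. Compound 4 (`O=C(CCl)NC(=O)Nc1ccc(Oc2ccccc2)cc1`) differs from compound 3 in one place (phenyl in place of cyclopentyl on an oxygen on an aromatic ring) with phenyl in place of cyclopentyl on an oxygen on an aromatic ring. Among the compounds with values here, the one measured step that bears on this is a 2.1-fold higher number from compound 2 to compound 3 (0.32 log units; beyond the scatter) and it was modest, with cyclopentyloxy in place of phenyl on an aromatic carbon. Compound 4 keeps the oxygen of compound 3 but carries the phenyl of compound 2 (1400 nM) so a partial return is expected. The expected step is small and downward (a 1.5-fold lower number from compound 3 to compound 4 (0.16 log units; within the scatter)) and probably within the scatter. For compound 4 the estimated value is 2000 nM with 900 nM to 4500 nM as its likely range.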

Compound 4, concentration for 50% growth inhibition: 4200 nM
Beside the measured number, compound 4's estimate is 2.1-fold (0.32 log units) below it; the range from low to high includes it.
By their numbers in this assay, from the lowest: compound 2; then compounds 3, 4 and 1 (each within the scatter of the next).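

In this assay, changing the ring on the oxygen gives a 1.4-fold higher number from compound 3 to compound 4 (0.16 log units; within the scatter) and so does not separate phenyl from cyclopentyl at this place. Phenoxy in place of phenyl gives a 3.0-fold higher number from compound 2 to compound 4 (0.48 log units; beyond the scatter) and shows that keeping a phenyl ring does not keep the number of compound 2 once an oxygen links it to the aromatic ring. No measurement shown here explains either step. Still open, on these data alone, is whether an amine, a carboxylic acid or a longer chain on that oxygen would move the number beyond the scatter.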